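One group exchanged on compound 1

The source may hold more compounds than are shown below. What is called first, only, known or untested is meant among the compounds shown, and "the series" means these compounds.

Measured values from a functional assay on 4T1 cells (Mus musculus) for cytotoxicity, read by MTT assay, with a stated time of 24 h (on this read-out higher numbers stand for weaker inhibition and lower numbers for stronger inhibition), are these
- compound 1 `O=C1/C(=C/c2ccccc2F)CN(Cc2cn(Cc3cccc(Cl)c3)nn2)C/C1=C\c1ccccc1F` gives 6100 nM
- compound 2 `Cc1ccc(/C=C2\CN(Cc3cn(Cc4ccc(F)cc4)nn3)C/C(=C\c3ccc(C)cc3)C2=O)cc1` gives 57200 nM
- compound 3 `O=C1/C(=C/c2ccccc2F)CN(C(=S)SCc2cn(Cc3ccccc3F)nn2)C/C1=C\c1ccccc1F` gives 30700 nM

Compound 1 has the lowest number of the three, and both other compounds lie beyond the scatter from it. Compound 4 `O=C1/C(=C/c2ccccc2F)CN(Cc2cn(Cc3ccc(F)cc3)nn2)C/C1=C\c1ccccc1F` keeps the core of compound 1 and has 4-fluorophenyl in place of 3-chlorophenyl on a saturated chain carbon bound to an aromatic nitrogen. Within the data shown here, no measured pair isolates this exchange, so the expectation is loose. With compound 1 at the low end (6100 nM), a modest rise near the edge of the scatter is expected in this assay, the expected change being a 2.1-fold higher number from compound 1 to compound 4 (0.33 log units; beyond the scatter) here. For compound 4 the estimated value is 13000 nM, within an expected range of 5000 nM to 35000 nM.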

Compound 4, half-maximal inhibitory concentration: 6400 nM
For compound 4 the middle estimate is 2.0-fold (0.31 log units) above the measured one, and the stated range covers the measured number.
By their numbers in this assay, from the lowest: compounds 1 and 4 (each within the scatter of the next); then compounds 3 and 2 (each within the scatter of the next).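

In this assay, among these compounds, the exchange gives a 1.0-fold higher number from compound 1 to compound 4 (0.02 log units; within the scatter), the first pair here that isolates a change at this place. With the core of compound 1 held fixed, 3-chlorobenzyl and 4-fluorobenzyl cannot be told apart, so this position accepts this particular swap without a readable effect on the number. Nothing measured here speaks to why the two compounds read alike. From the compounds shown here alone, whether an unsubstituted phenyl, a methoxyphenyl or a pyridine ring on that chain carbon would read apart from these two remains open. So does whether the same exchange reads alike on a different core.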